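The source may report more compounds than this note shows. Statements on the series, on what has been measured and on what is new or still open speak of the compounds shown alone.

Working notes on a four-compound set read in a functional assay on Raji cells (Homo sapiens); a lower number here means a stronger inhibitor, a higher number a weaker inhibitor. Compound 1 is `CCCCc1cn([C@H]2C[C@H](O)[C@@H](CO)O2)c(=O)[nH]c1=O` and compound 3 is `CCCc1cn([C@H]2C[C@H](O)[C@@H](CO)O2)c(=O)[nH]c1=O`; compound 2 is `CCCCCc1cn([C@H]2C[C@@H]3OP(=O)(O)OC[C@H]3O2)c(=O)[nH]c1=O` and compound 4, not yet measured, is `CCCCc1cn([C@H]2C[C@@H]3OP(=O)(O)OC[C@H]3O2)c(=O)[nH]c1=O`. In this assay compound 1 gives only a limit, > 500 ug/mL. Compound 3 likewise gives only a limit in this assay, > 500 ug/mL. Compound 2 also returns only a limit in this assay, > 500 ug/mL.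

The change from compound 1 to compound 3 is hydrogen in place of methyl on a saturated chain carbon, three bonds along the chain from an aromatic carbon and the step it made is a step that the two limits leave unreadable from compound 1 to compound 3; with both ends at the limit, the size of that step cannot be read. The change from compound 2 to compound 4 is hydrogen in place of methyl on a saturated chain carbon, four bonds along the chain from an aromatic carbon. It is the same kind of change, though the place is not the same: here the methyl is removed from a saturated chain carbon four bonds along the chain from an aromatic carbon, rather than three bonds along. How the core of compound 1 differs from the core of compound 2 is not broken down here. What the measurements show is only this: the limit of > 500 ug/mL in this assay, at which 3 of the 3 values shown sit.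

Since nothing in the set gives a readable step, the expectation for compound 4 rests on the limits of compound 1, compound 3 and compound 2, and the expected step is a step that the limit leaves unreadable from compound 2 to compound 4. Compound 4 is accordingly estimated at 1000 ug/mL, with a range from 300 ug/mL to 3000 ug/mL, and most probably this assay will again report only a limit for compound 4.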

Compound 4, concentration for 50% inhibition: 82 ug/mL
Beside the measured number, compound 4's estimate is 12-fold (1.09 log units) above it, and the stated range ends above it.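

In this assay, hydrogen in place of methyl on a saturated chain carbon, four bonds along the chain from an aromatic carbon, gives an at least 6.0-fold lower number from compound 2 to compound 4 (0.78 log units; beyond the scatter); one end of this step is a limit, so the step fixes only how small it can be, not its full size. Going by these compounds alone, this shows that the change can matter on the core of compound 2, but it does not show that the change carries over to the core of compound 1, where the one step of this kind sits three bonds along the chain rather than four and cannot be read, with both of its ends at a limit. The result therefore rests on one readable step, on one core and at one place, and compound 4 is the only compound in the set with a measured number rather than a limit, which leaves no second step to set against it: the limit of > 500 ug/mL in this assay, at which 3 of the 4 values shown sit.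

The compounds shown leave open whether shortening the chain further on the core of compound 2 would continue in the same direction, and whether any chain on the core of compound 1 gives a readable number. They also leave open how a longer chain, or an amine or a carboxylic acid carried on the chain, would read in this assay on either core.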